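This account rests on a few compounds, and the source may have more. Where it says the series, first, only, none or still open, it means among the compounds named here.

Measured compounds:
Compound 1, `CC(O)(CSc1ccccc1C(F)(F)F)C(=O)Nc1cccc(S(F)(F)(F)(F)F)c1`, gives 21000 nM in a functional assay on VCaP cells (Homo sapiens) for antiproliferative activity, read by propidium iodide staining, with a stated time of 96 h; on this read-out lower numbers stand for stronger inhibition and higher numbers for weaker inhibition.
Compound 2, `CC(O)(CSc1ccccc1OC(F)(F)F)C(=O)Nc1cccc(S(F)(F)(F)(F)F)c1`, gives 12600 nM in this assay.
Compound 3, `CC(O)(COc1cccc(C(F)(F)F)c1)C(=O)Nc1ccc(S(F)(F)(F)(F)F)cc1`, gives 24700 nM in this assay.

Compounds 1 and 2 share a core and differ only at one point on the aromatic ring: trifluoromethoxy in place of trifluoromethyl on an aromatic carbon. That exchange gave a 1.7-fold lower number from compound 1 to compound 2 (0.22 log units; within the scatter), so the two numbers cannot be told apart with confidence. Compound 3 has a different core from compound 1; how the two cores differ is not broken down here. All three measured numbers lie within the usual scatter of one another, so none of them can be called more or less active than the others.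

Compound 4, `CC(O)(COc1cccc(OC(F)(F)F)c1)C(=O)Nc1ccc(S(F)(F)(F)(F)F)cc1`, has not yet been measured. It relates to compound 3 as compound 2 relates to compound 1: trifluoromethoxy in place of trifluoromethyl on an aromatic carbon. The surrounding is not identical, since in the earlier pair the group sat ortho to a large group and here it sits meta to a large group, so this is the same kind of change rather than the same change. Given that the earlier exchange produced a step within the scatter, the step from compound 3 to compound 4 is expected to be of similar size, a 1.6-fold lower number from compound 3 to compound 4 (0.22 log units; within the scatter). Compound 4 is therefore estimated at 15000 nM in this assay, with a plausible range from 7000 nM to 35000 nM.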

Compound 4, half-maximal inhibitory concentration: 18300 nM
For compound 4 the middle estimate is 1.2-fold (0.09 log units) below the measured one, and the stated range covers the measured number.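

In this assay, putting trifluoromethoxy in place of trifluoromethyl on the second core gave a 1.3-fold lower number from compound 3 to compound 4 (0.13 log units; within the scatter), so on this core too the two numbers cannot be told apart with confidence. Seen side by side, the exchange behaves alike on both cores, with no measurable difference between the two steps: the same change on two cores in this assay, a 1.7-fold lower number (0.22 log units; within the scatter) from compound 1 to compound 2 and a 1.3-fold lower number (0.13 log units; within the scatter) from compound 3 to compound 4, 1.2-fold (0.09 log units) apart, within the scatter of two such steps

For the compounds shown here, this shows only that the exchange left the number within the scatter on both cores; it does not show that trifluoromethoxy truly improves activity, and two pairs cannot establish how the change would behave on further cores.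

The compounds shown leave open whether a quite different group on that aromatic carbon, such as a nitrile, an amine or a carboxylic acid, would move the number beyond the scatter. They also leave open which of the differences between the two cores matters, since no pair shown changes just one of those differences.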